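Extending a Hydroxymethyl Chain on Two Lactone Cores

This account rests on a few compounds, and the source may have more. Where it says the series, first, only, none or still open, it means among the compounds named here.

Three compounds have been measured in a functional assay on NCI/ADR-RES cells (Homo sapiens) for antiproliferative activity, read by sulforhodamine B assay, with a stated time of 48 h; on this read-out higher numbers stand for weaker inhibition of growth and lower numbers for stronger inhibition of growth:

compound 1 `COc1ccc2cc(CO)oc(=O)c2c1`: 160 ug/mL
compound 2 `COc1ccc2cc(CCCO)oc(=O)c2c1`: 28.1 ug/mL
compound 3 `COc1ccc2c(c1)C(=O)OC(CO)C2`: >= 250 ug/mL

For compound 3 that figure is a limit of the assay and not a number, (the limit of >= 250 ug/mL in this assay, at which 1 of the 3 values shown sits). How the core of compound 3 differs from the core of compound 1 is not broken down here.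

Compound 2 carries 2-hydroxyethyl in place of hydroxy on a saturated chain carbon bound to an aromatic carbon, and in this assay the step is a 5.7-fold lower number from compound 1 to compound 2 (0.76 log units; beyond the scatter).

Compound 4 `COc1ccc2c(c1)C(=O)OC(CCCO)C2` has not yet been measured. It carries 2-hydroxyethyl in place of hydroxy on a saturated chain carbon bound to a saturated ring carbon. This is the same kind of change as that from compound 1 to compound 2, but the place differs: on a saturated chain carbon bound to an aromatic carbon in the first pair, on a saturated chain carbon bound to a saturated ring carbon in the second.

Compound 4 is expected to move by about an at least 3.1-fold lower number from compound 3 to compound 4 (0.49 log units; beyond the scatter), an expectation that rests on the step of a 5.7-fold lower number from compound 1 to compound 2 (0.76 log units; beyond the scatter) and is loose since compound 3 gives only a limit. Compound 4 is therefore estimated at 80 ug/mL, expected to lie between 30 ug/mL and 250 ug/mL.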

Compound 4, concentration for 50% growth inhibition: 93.3 ug/mL
For compound 4 the middle estimate is 1.2-fold (0.07 log units) below the measured one; the range from low to high includes it.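

In this assay, the change from hydroxymethyl to 3-hydroxypropyl again goes with a lower number on the second core, with an at least 2.6-fold lower number from compound 3 to compound 4 (0.42 log units; beyond the scatter), so the direction of the step seen on the core of compound 1 carries over to the core of compound 3. Compound 3 stands at >= 250 ug/mL, which is a limit of the assay and not a number, so the step on this core has a floor but no exact size. The two cores therefore agree in direction, but this pair of steps does not show whether the change is worth the same amount on each: the same change on two cores in this assay, a 5.7-fold lower number (0.76 log units; beyond the scatter) from compound 1 to compound 2 and an at least 2.6-fold lower number (0.42 log units; beyond the scatter) from compound 3 to compound 4; the limit leaves it open whether they differ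

The compounds shown leave open whether a longer chain than 3-hydroxypropyl would lower the number further on either core. They also leave open whether the step would survive with an amine or a carboxylic acid in place of the hydroxy on the chain.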